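Replacing acetyl with methyl on a ring nitrogen

This account rests on a few compounds, and the source may have more. Where it says the series, first, only, none or still open, it means among the compounds named here.

Three compounds that share one core and differ in the group on a sulfonyl sulfur have been tested in an ADME assay on microsomes from liver (Homo sapiens) for pharmacokinetics, read by LC-MS, with a stated time of 60 min, tested at 1 uM; a higher number here means faster removal of the compound, a lower number slower removal. In that test compound 1 `O=C(NCc1ccc(S(=O)(=O)c2cncc(C(F)(F)F)c2)cc1)N1Cc2ccncc2C1` gives 13 mL/min/kg, and compound 2 `CCCn1cc(S(=O)(=O)c2ccc(CNC(=O)N3Cc4ccncc4C3)cc2)cn1` gives 11 mL/min/kg, which amounts to a 1.2-fold lower number from compound 1 to compound 2 (0.07 log units; within the scatter). Compound 3 `CC(=O)N1CCC(S(=O)(=O)c2ccc(CNC(=O)N3Cc4ccncc4C3)cc2)CC1`, which carries 1-acetylpiperidin-4-yl on the sulfur, gives 6 mL/min/kg. That places it clearly under one neighbour, with a 2.2-fold lower number from compound 1 to compound 3 (0.34 log units; beyond the scatter), but not clearly under the other, with a 1.8-fold lower number from compound 2 to compound 3 (0.26 log units; within the scatter).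

Compound 4 `CN1CCC(S(=O)(=O)c2ccc(CNC(=O)N3Cc4ccncc4C3)cc2)CC1` keeps everything in compound 3 except one small piece: methyl in place of acetyl on an amine nitrogen in a ring. In words, this is methyl in place of acetyl on an amine nitrogen in a ring. Among the measured compounds shown here, no measured pair makes this exact swap, so the three steps above are only a rough guide. Each of them replaces the whole group on the sulfur, and the largest is still modest, at a 2.2-fold lower number from compound 1 to compound 3 (0.34 log units; beyond the scatter). A smaller edit is therefore expected to give a step of similar or smaller size, and the data do not firmly fix its direction. The expected step is a 1.3-fold higher number from compound 3 to compound 4 (0.12 log units; within the scatter), a small one. For compound 4 the estimated clearance is 8 mL/min/kg, with a range of 4 mL/min/kg to 17 mL/min/kg.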

Compound 4, clearance: 11 mL/min/kg
Compound 4: the middle estimate sits 1.4-fold (0.14 log units) below what was measured; the measured number falls inside the stated range.
By their numbers in this assay, from the lowest: compounds 3, 2, 4 and 1 (each within the scatter of the next, the first and the last beyond it).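

Among the compounds shown here, this is the first direct reading of the swap on the amine nitrogen of the ring: in this assay, exchanging the acetyl group, with its 3 heavy atoms, for methyl, with 1, gives a step that stays within the usual scatter (a 1.8-fold higher number from compound 3 to compound 4 (0.26 log units; within the scatter)), so this one pair cannot firmly establish a direction for the change. Compound 4 also cannot be separated from the compounds bearing quite different groups on the sulfonyl sulfur (no change at the digits printed from compound 2 to compound 4 (within the scatter); a 1.2-fold lower number from compound 1 to compound 4 (0.07 log units; within the scatter)), whereas compound 3 stood clearly apart from compound 1, so the clear separation seen with 1-acetylpiperidin-4-yl is not seen with 1-methylpiperidin-4-yl. No independent evidence is available to explain these numbers.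

The compounds shown leave open what other groups on this ring nitrogen would give, such as a plain hydrogen, an ethyl group, a propanoyl group or a methylsulfonyl group. They also leave open whether a series of such groups would show a consistent trend or whether the acetyl and methyl pair would remain within the scatter on repeated measurement.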